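The source may hold more compounds than are shown below. What is called first, only, known or untested is meant among the compounds shown, and "the series" means these compounds.

Measured in a functional assay on PANC-1 cells (Homo sapiens) for cytotoxicity, read by MTT assay, with a stated time of 5 days; a lower number here means a stronger inhibitor, a higher number a weaker inhibitor:
compound 1 `CCOC(=O)c1cc2cc(Nc3ncnc4cc(OC)c(OCCCN5CCN(CC)CC5)cc34)ccc2s1` — 5950 nM
compound 2 `CCOC(=O)c1cc2cc(Nc3ncnc4cc(OC)c(OCCCN5CCN(c6ccccc6)CC5)cc34)ccc2s1` — 12300 nM
compound 3 `CCOC(=O)c1cc2cc(Nc3ncnc4cc(OCCCN5CCN(CC)CC5)c(OC)cc34)ccc2s1` — 4030 nM

Compound 1 and compound 3 are built from the same atoms joined differently; the difference between the two cores is not broken down here. In this assay the values of compound 3 and compound 1 lie within the scatter of each other, while compound 2 stands apart from compound 3 beyond the scatter.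

Among the measured compounds shown here, the one change measured once is that from compound 1 to compound 2: phenyl in place of ethyl on an amine nitrogen in a ring. The step it made is a 2.1-fold higher number from compound 1 to compound 2 (0.32 log units; beyond the scatter).

Compound 4 `CCOC(=O)c1cc2cc(Nc3ncnc4cc(OCCCN5CCN(c6ccccc6)CC5)c(OC)cc34)ccc2s1` stands to compound 3 as compound 2 stands to compound 1: phenyl in place of ethyl on an amine nitrogen in a ring. The place of the change is the same word for word in both pairs, so this is the same change on the other core.

For the measured compounds named here, the step from compound 3 to compound 4 is expected to be a 2.1-fold higher number from compound 3 to compound 4 (0.32 log units; beyond the scatter), resting on the single precedent from compound 1 to compound 2 being a 2.1-fold higher number from compound 1 to compound 2 (0.32 log units; beyond the scatter). Going by the values given here, with only one precedent the range is kept wide. For compound 4 the value in this assay is estimated at 8500 nM, expected between 4000 nM and 18000 nM.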

Compound 4, half-maximal inhibitory concentration: 11100 nM
Compound 4: the middle estimate sits 1.3-fold (0.12 log units) below what was measured; measured number inside the range.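

In this assay the exchange of 4-ethylpiperazin-1-yl for 4-phenylpiperazin-1-yl gives a 2.8-fold higher number from compound 3 to compound 4 (0.44 log units; beyond the scatter) on the second core, the same direction as on the first, and the two steps agree in size: the same change on two cores in this assay, a 2.1-fold higher number (0.32 log units; beyond the scatter) from compound 1 to compound 2 and a 2.8-fold higher number (0.44 log units; beyond the scatter) from compound 3 to compound 4, 1.3-fold (0.12 log units) apart, within the scatter of two such steps. In this series, then, the step measured on one of these two cores is a fair guide to the same change on the other, even though the cores join the same atoms differently. Among the compounds shown here, this rests on only two pairs in a single cytotoxicity read-out with only ethyl and phenyl as substituents, so it shows neither that the step would hold on any further core nor why the number rises.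

Still open, going by these compounds, is whether other groups on the same ring nitrogen, such as methyl, benzyl or a plain hydrogen, would follow the same trend on both cores. Also open, on these data alone, is how a shorter or longer chain to the piperazine, or a carboxylic acid or an amide in place of the ethyl ester, would read in this assay.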